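The compounds below may be only part of what the source reports. "The series", "measured", "known", "first", "only" and "open" are said of these compounds alone.

- Compound 1 `C[C@@H]1CN(c2ccc3c(n2)NC(=O)CO3)[C@H](c2ccccc2F)CO1` gives 3.1
- Compound 2 `C[C@@H]1CN(c2ccc3c(n2)NC(=O)CO3)[C@H](c2cccc(F)c2)CO1` gives 3.1

In a physicochemical assay for lipophilicity (on this read-out higher numbers stand for higher lipophilicity and lower numbers for lower lipophilicity), compound 1 stands level with compound 2 (3.1). Compound 3 `C[C@@H]1CN(c2ccc3c(n2)NC(=O)CO3)[C@H](c2ccc(F)cc2)CO1` differs from compound 2 in one place (4-fluorophenyl in place of 3-fluorophenyl on a saturated ring carbon), with 4-fluorophenyl in place of 3-fluorophenyl on a saturated ring carbon. Among the compounds with values here, the one measured step that bears on this change is also an exchange of one fluorophenyl for another on that carbon (no change at the digits printed from compound 1 to compound 2 (within the scatter)), and it stays within the scatter. No shift beyond the scatter is therefore expected in this assay (no change at the digits printed from compound 2 to compound 3 (within the scatter)). The estimate for compound 3 is 3.1 (expected range 2.8 to 3.4).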

Compound 3, distribution coefficient: 3.2
Compound 3: the middle estimate sits 0.10 log units below what was measured; low and high end bracket the measured number.
By their numbers in this assay, from the lowest: compounds 1, 2 and 3 (each within the scatter of the next).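

In this assay, 4-fluorophenyl in place of 3-fluorophenyl on this saturated ring carbon gives a number 0.10 log units higher from compound 2 to compound 3 (within the scatter), and 4-fluorophenyl in place of 2-fluorophenyl gives a number 0.10 log units higher from compound 1 to compound 3 (within the scatter). The 4-fluorophenyl group thus joins the other two fluorophenyl groups within the scatter, so all three placements of the fluorine on this phenyl ring read alike in this assay. Nothing given here explains this result. The compounds shown leave open how an unsubstituted phenyl, a pyridine ring or a primary amine on this carbon would read in this assay.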